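From Fluoro to Chloro: Estimating Compound 3

This account rests on a few compounds, and the source may have more. Where it says the series, first, only, none or still open, it means among the compounds named here.

Two compounds have so far been measured in an assay on isolated protein for binding affinity to 5-hydroxytryptamine receptor 1F (Homo sapiens); a higher number here means a weaker inhibitor, a lower number a stronger inhibitor:

Compound 1, `CN1CCC(c2noc3ccc(NC(=O)c4ccc(F)cc4)cc23)CC1`, gives 17 nM.
Compound 2, `CN1CCC(c2noc3ccc(NC(=O)c4ccc(F)cc4F)cc23)CC1`, gives 12 nM.

Compound 2 holds the lower of these two numbers, yet the step of a 1.4-fold lower number from compound 1 to compound 2 (0.15 log units; within the scatter) lies within the usual scatter, so the two compounds cannot be told apart on these data.

Compound 3, `CN1CCC(c2noc3ccc(NC(=O)c4ccc(F)cc4Cl)cc23)CC1`, differs from compound 2 in a single place: chloro in place of fluoro on an aromatic carbon. Within the data shown here, no measured step describes this exchange. Among the measured compounds shown here, the only step available, a 1.4-fold lower number from compound 1 to compound 2 (0.15 log units; within the scatter), concerns a different change and showed no movement beyond the scatter. With nothing pointing in either direction, the expectation for compound 3 is a number close to that of compound 2, which is the step of no change at the digits printed from compound 2 to compound 3 (within the scatter), and the estimate for compound 3 in this assay is 12 nM, expected to fall between 5 nM and 30 nM.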

Compound 3, inhibition constant: 3.6 nM
Compound 3: the middle estimate sits 3.3-fold (0.52 log units) above what was measured; the whole stated range lies above it.
By their numbers in this assay, from the lowest: compound 3; then compounds 2 and 1 (each within the scatter of the next).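

At the position ortho to a large group, the choice of atom turns out to matter: in this assay, fluoro in place of hydrogen gave a 1.4-fold lower number from compound 1 to compound 2 (0.15 log units; within the scatter), whereas chloro in place of fluoro gives a 3.3-fold lower number from compound 2 to compound 3 (0.52 log units; beyond the scatter). Set against the hydrogen of compound 1, chloro gives a 4.7-fold lower number from compound 1 to compound 3 (0.67 log units; beyond the scatter), so this place on the ring is not indifferent to what sits there, and compound 3 has the lowest number of the three. Nothing available here accounts for why chloro and fluoro part ways at this position.

From the compounds shown here alone, whether a larger atom such as bromine, or a group such as methyl or methoxy, would lower the number further remains open. So does whether chloro would give a similar step without the fluoro group on the same ring.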